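A few compounds are considered here, and "the series" means these few. Any claim that something is new, unique, unknown or untested is made for them only; others in the source may bear on it.

Working notes on the series. In a toxicity assay on Huh-7.5 cells (Homo sapiens) for inhibition, read by MTT assay, with a stated time of 96 h (a lower number here means that less compound is tolerated, a higher number that more compound is tolerated), compound 2 (`CCC(=O)Nc1cc(C(=O)Nc2ccc(OC)cc2)ccc1OC(C)C`) gives 113000 nM, the highest of the three numbers in hand. Compound 3 (`COc1ccc(NC(=O)c2ccc(OC(C)C)c([N+](=O)[O-])c2)cc1`) gives 23400 nM, and compound 1 (`CN1CCN(Cc2ccc(NC(=O)c3ccc(OCCCCl)c(F)c3)cc2C(F)(F)F)CC1`) gives 8800 nM, the lowest of the three.

The next compound is compound 4 (`CCC(=O)Nc1cc(C(=O)Nc2ccc(OC)cc2)ccc1OCCCN(C)C`), which is related to compound 2 by 3-(dimethylamino)propyl in place of isopropyl on an oxygen on an aromatic ring.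

Among the measured compounds shown here, only one measured step starts from compound 2: a 4.8-fold lower number from compound 2 to compound 3 (0.68 log units; beyond the scatter). It is modest and lies beyond the scatter, but it replaces the propanoylamino group and leaves the isopropoxy group in place, so it bears on the new change only indirectly, as a guide to size. For the measured compounds named here, no measured pair isolates a change on the oxygen. Going by the values given here, compound 1 has a different structure from compound 2 in several places, so compound 1 at 8800 nM sets only a lower mark for the series so far.

With compound 2 at the top of the range, any step in this assay seems more likely to go down than up. A modest step is expected, similar in size to the measured one, and the estimate is a 2.8-fold lower number from compound 2 to compound 4 (0.45 log units; beyond the scatter). For compound 4 the estimated value is 40000 nM, with an expected range of 13000 nM to 120000 nM.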

Compound 4, half-maximal cytotoxic concentration: 154000 nM
Compound 4: the middle estimate sits 3.9-fold (0.59 log units) below what was measured; the measured number lies above the stated range.
By their numbers in this assay, from the lowest: compound 1; then compound 3; then compounds 2 and 4 (each within the scatter of the next).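

Working notes, continued. Among the compounds shown here, on an oxygen on an aromatic ring, 3-(dimethylamino)propyl in place of isopropyl gives a 1.4-fold higher number from compound 2 to compound 4 (0.13 log units; within the scatter) in this assay; this is the first measured pair that isolates a change at this position, and the two compounds cannot be told apart in this read-out. The entering chain has 6 heavy atoms against 3, and 1 hydrogen-bond acceptor against 0, so in this one pair a larger, nitrogen-bearing chain on the oxygen leaves the number within the scatter, whereas a 4.8-fold lower number from compound 2 to compound 3 (0.68 log units; beyond the scatter), a change at the propanoylamino group, lies beyond it. Nothing in hand accounts for this result or says what lies behind it.

Open, going by these compounds, is whether the same oxygen would read alike with a longer chain, a carboxylic acid or a morpholine at the end of the chain, since one amine-bearing chain says nothing about the others. Also open, on these data alone, is whether 3-(dimethylamino)propyl in place of isopropyl would read the same with nitro in place of propanoylamino, the arrangement of compound 3, which still carries the isopropoxy group.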